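Fluoro on the benzyl arm of a sigma-2 ligand

A few compounds are considered here, and "the series" means these few. Any claim that something is new, unique, unknown or untested is made for them only; others in the source may bear on it.

Measured so far:
- compound 1, `O=C(c1c2c(nn1-c1ccccc1)CCC(NCc1ccccc1)C2)N1CCCCC1`: 126 nM
- compound 2, `O=C(c1c2c(nn1-c1ccc(F)cc1)CCC(NCc1ccc(F)cc1)C2)N1CCCCC1`: > 10000 nM; > 10000 nM (2 entries)
- compound 3, `O=C(c1nn(-c2ccccc2)c2c1CC(NCc1ccc(F)cc1)CC2)N1CCCCC1`: > 10000 nM

Among the measured compounds shown here, compound 1, `O=C(c1c2c(nn1-c1ccccc1)CCC(NCc1ccccc1)C2)N1CCCCC1`, is the only compound of the three with a number in an assay on isolated protein for antagonist activity at Sigma intracellular receptor 2 (Homo sapiens), read by scintillation counting, with a stated time of 120 min, in the presence of a further agent that is not named here (a higher number here means a weaker inhibitor, a lower number a stronger inhibitor), where compound 1 gives 126 nM. Compound 2, `O=C(c1c2c(nn1-c1ccc(F)cc1)CCC(NCc1ccc(F)cc1)C2)N1CCCCC1`, reaches only the limit of this assay, > 10000 nM; > 10000 nM (2 entries), twice over. Compound 3, `O=C(c1nn(-c2ccccc2)c2c1CC(NCc1ccc(F)cc1)CC2)N1CCCCC1`, likewise stops at the limit, > 10000 nM. For the measured compounds named here, both limits sit at the limit of > 10000 nM in this assay, at which 1 of the 3 values shown sits, so the two fluorinated compounds show no number at all, and no single step between measured compounds can be drawn.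

Compound 4, `O=C(c1c2c(nn1-c1ccccc1)CCC(NCc1ccc(F)cc1)C2)N1CCCCC1`, differs from compound 1 in one place: fluoro in place of hydrogen on an aromatic carbon. Compound 2 carries this same 4-fluorobenzyl group together with a second fluorine, and its limit is the only hint at hand. On that basis the step from compound 1 to compound 4 in this assay is expected to run toward weaker inhibition, by more than the usual scatter, a 5.0-fold higher number from compound 1 to compound 4 (0.70 log units; beyond the scatter). Compound 4 is therefore estimated at 630 nM, within 150 nM to 5000 nM.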

Compound 4, inhibition constant: 158 nM
Beside the measured number, compound 4's estimate is 4.0-fold (0.60 log units) above it; low and high end bracket the measured number.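

In this assay, the change from benzyl to 4-fluorobenzyl on the core of compound 1 gives a 1.3-fold higher number from compound 1 to compound 4 (0.10 log units; within the scatter), so at this position, on an aromatic carbon para to a large group, fluoro keeps a measured number. The earlier compounds shown here could not show this, since compound 2, which carries the same 4-fluorobenzyl group, stays at a limit of the assay: the limit of > 10000 nM in this assay, at which 1 of the 4 values shown sits. The limit of compound 2 therefore does not come with the 4-fluorobenzyl group alone, as compound 4 has that group without the second fluorine.

The compounds shown do not tell whether that second fluorine would reach the limit on a plain benzyl arm. They also leave open what a chloro or methoxy group would do in place of the fluoro at this position.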